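The source may report more compounds than this note shows. Statements on the series, on what has been measured and on what is new or still open speak of the compounds shown alone.

Compound 1 `CCc1ccccc1NC(=O)N[C@H](C)c1ccccc1`: 92%
Compound 2 `CCc1ccccc1NC(=O)N[C@@H](C)c1ccccc1`: 95%

In an ADME assay on the whole organism with Oryza sativa as the target, tested at 10 uM (a lower number here means a stronger effect, a higher number a weaker effect of the compound at the concentration tested), compound 1 gives 92% and compound 2 gives 95%, a change of a number 3 percentage points higher from compound 1 to compound 2 (within the scatter); the pair is distinguished only by the fact that compounds 1 and 2 differ only in the configuration as drawn. Compound 2 thus holds the top of the two numbers shown, with compound 1 nearest and inside the scatter. Compound 3 `CC(C)c1ccccc1NC(=O)N[C@@H](C)c1ccccc1` differs from compound 2 by methyl in place of hydrogen on a saturated chain carbon bound to an aromatic carbon and a saturated chain carbon. Within the data shown here, the single measured step concerns configuration alone and does not bear on methyl in place of hydrogen, so no measured step informs this change. Compound 3 is expected to show a number 3 percentage points lower from compound 2 to compound 3 (within the scatter), no step beyond the scatter, with an estimate of 92% and a range from 75% to 100%.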

Compound 3, a percentage reported as activity, at one concentration (the size of the read-out at that concentration, not a potency): 93%
Compound 3: middle estimate off by 1 percentage points, on the low side; measured number inside the range.
By their numbers in this assay, from the lowest: compounds 1, 3 and 2 (each within the scatter of the next).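

Among these compounds, for this assay the change from ethyl to isopropyl, methyl in place of hydrogen on a saturated chain carbon bound to an aromatic carbon and a saturated chain carbon, gives a number 2 percentage points lower from compound 2 to compound 3 (within the scatter) and so adds the first reading at this position. The earlier pair differed in configuration alone and said nothing about this place, where this added methyl leaves the number within the scatter. Nothing on record bears on this change.

As far as these compounds go, whether a longer chain such as propyl or a tert-butyl group at this position would behave the same remains open. So does the reading for an amine or a carboxylic acid there.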